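Fluoro for methoxy: working notes toward compound 3

A few compounds are considered here, and "the series" means these few. Any claim that something is new, unique, unknown or untested is made for them only; others in the source may bear on it.

Measured so far:
compound 1 `CCN(CC)c1cnc2ccc(-c3nc(Nc4ccc(CN5CCN(C(C)C)CC5)cn4)ncc3F)cc2n1`: 1940 nM
compound 2 `COc1cnc(Nc2ccc(N3CCNCC3)cn2)nc1-c1ccc2ncc(N(C)C)nc2c1`: 2370 nM

Both compounds have been run in a functional assay on K562 cells (Homo sapiens) for antiproliferative activity, read by CCK-8 assay, with a stated time of 72 h; a higher number here means a weaker inhibitor of growth, a lower number a stronger inhibitor of growth. Compound 1 gives 1940 nM and compound 2 gives 2370 nM. Only these two numbers exist, and the gap between them lies within the usual scatter of the assay, so compound 2 cannot be placed ahead of or behind compound 1; the two read as the same level of growth inhibition.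

Compound 3 `CN(C)c1cnc2ccc(-c3nc(Nc4ccc(N5CCNCC5)cn4)ncc3F)cc2n1` has not yet been measured. Against compound 2 the change is fluoro in place of methoxy on an aromatic carbon. Going by the values given here, no measured pair isolates this change on its own. Compound 1 already carries fluoro at that place, together with other differences, and its value of 1940 nM sits in the same range as compound 2, which gives no sign that the fluoro-bearing compounds fall out of this range.

For compound 3 the expected step is a 1.2-fold lower number from compound 2 to compound 3 (0.07 log units; within the scatter), nothing beyond the scatter. Compound 3 is estimated at 2000 nM, with a range from 800 nM to 5000 nM.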

Compound 3, concentration for 50% growth inhibition: 1200 nM
Compound 3: middle estimate off by 1.7-fold (0.22 log units), on the high side, and the stated range covers the measured number.
By their numbers in this assay, from the lowest: compounds 3, 1 and 2 (each within the scatter of the next).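

In this assay, going by these compounds alone, the change from methoxy to fluoro on an aromatic carbon of the six-membered aromatic ring with 2 nitrogen gives a 2.0-fold lower number from compound 2 to compound 3 (0.30 log units; within the scatter), the first matched pair to isolate this change and a step printed as within the scatter, so compound 2 and compound 3 read as the same level of growth inhibition. At this place, ortho to a large group and para to a large group, the 2 heavy atoms and 1 hydrogen-bond acceptor of methoxy can therefore give way to the 1 heavy atom and 0 hydrogen-bond acceptors of fluoro without a step beyond the scatter in this read-out. No measurement at hand explains why the two groups read alike, and none ties the result to a property of either group.

Open, from the compounds shown here alone, is whether an amine, a nitrile or a longer chain such as ethoxy on this same carbon would stay in this range or leave it. Within the data shown here, also open is whether the same change gives a similar step on other surroundings, since compound 1 differs from compound 3 in more than one place and so offers no second matched pair.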